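A 3-iodophenyl in place of 4-bromophenyl

The source may report more compounds than this note shows. Statements on the series, on what has been measured and on what is new or still open speak of the compounds shown alone.

In a functional assay on MCF7 cells (Homo sapiens) for inhibition, read by MTT assay (on this read-out lower numbers stand for stronger inhibition and higher numbers for weaker inhibition), compound 2 (`COc1cc2ncnc(Nc3ccc(NC(=O)c4ccc(Br)cc4)cc3)c2cc1OC`) gives 43000 nM and compound 1 (`CCc1ccc(C(=O)Nc2ccc(Nc3ncnc4cc(OC)c(OC)cc34)cc2)cc1`) gives 65000 nM so the two lie within the scatter of each other. Compound 3 (`COc1cc2ncnc(Nc3ccc(NC(=O)c4cccc(I)c4)cc3)c2cc1OC`) brings one change from compound 2 (3-iodophenyl in place of 4-bromophenyl on a carbonyl carbon) with 3-iodophenyl in place of 4-bromophenyl on a carbonyl carbon. Going by the values given here, the only measured step (a 1.5-fold lower number from compound 1 to compound 2 (0.18 log units; within the scatter)) put bromo in place of ethyl on an aromatic carbon and stayed within the scatter, and no measured compound carries 3-iodophenyl. So no step beyond the scatter is expected in this assay and the estimated change (a 1.1-fold lower number from compound 2 to compound 3 (0.03 log units; within the scatter)) is small. In this assay compound 3 is estimated at 40000 nM (range 15000 nM to 90000 nM).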

Compound 3, half-maximal inhibitory concentration: 30000 nM
Compound 3: middle estimate off by 1.3-fold (0.12 log units), on the high side; the measured number falls inside the stated range.
By their numbers in this assay, from the lowest: compounds 3, 2 and 1 (each within the scatter of the next, the first and the last beyond it).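

In this assay, the position on the carbonyl carbon accepts 3-iodophenyl in place of 4-bromophenyl with little consequence: a 1.4-fold lower number from compound 2 to compound 3 (0.16 log units; within the scatter). Going by these compounds alone, replacing 4-ethylphenyl with 3-iodophenyl gives a 2.2-fold lower number from compound 1 to compound 3 (0.34 log units; beyond the scatter), the first step in this set to pass the scatter, though only modestly. No supporting data explain either step. The names 3-iodophenyl and 4-bromophenyl differ in both the halogen and its number on the ring, so the compounds shown cannot separate those two changes. On these data alone, whether an amine or a carboxylic acid on this ring would shift the number remains open.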